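Amide and urea variations on the shared core

The source may hold more compounds than are shown below. What is called first, only, known or untested is meant among the compounds shown, and "the series" means these compounds.

Compound 3 `COc1cc(-c2nn(-c3cccc(NC(=O)Nc4ccc(Cl)c(C(F)(F)F)c4)c3)cc2-c2ccncc2)ccc1Cl` gives the highest of the three numbers in a functional assay on NCI-H522 cells (Homo sapiens) for inhibition, read by sulforhodamine B assay, with a stated time of 48 h (on this read-out lower numbers stand for stronger inhibition of growth and higher numbers for weaker inhibition of growth), at 1140 nM, though all three lie within the scatter of one another. Compound 1 `COc1cc(-c2nn(-c3cccc(NC(=O)c4cccc(C(F)(F)F)c4)c3)cc2-c2ccncc2)ccc1Cl` gives 1050 nM and compound 2 `COc1cc(-c2nn(-c3cccc(NC(=O)Nc4ccc(Cl)c(Cl)c4)c3)cc2-c2ccncc2)ccc1Cl` gives 811 nM. Compound 4 `COc1cc(-c2nn(-c3cccc(NC(=O)c4ccccc4)c3)cc2-c2ccncc2)ccc1Cl` differs from compound 3 in one place: phenyl in place of (4-chloro-3-(trifluoromethyl)phenyl)amino on a carbonyl carbon. The most relevant measured step is a 1.1-fold higher number from compound 1 to compound 3 (0.04 log units; within the scatter), which exchanged the same aryl group on the carbonyl carbon; a 1.3-fold lower number from compound 1 to compound 2 (0.11 log units; within the scatter) and a 1.4-fold higher number from compound 2 to compound 3 (0.15 log units; within the scatter) were likewise small. Going by the values given here, no measured compound carries a bare phenyl on the carbonyl carbon, so the loss of the chloro and trifluoromethyl is untested. In this assay the expected step is a 1.1-fold higher number from compound 3 to compound 4 (0.06 log units; within the scatter), not beyond the scatter. Compound 4 is estimated at 1300 nM, within 500 nM to 3500 nM.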

Compound 4, concentration for 50% growth inhibition: 317 nM
The estimate for compound 4 lay 4.1-fold (0.61 log units) above the measured number; measured number below the stated range.
By their numbers in this assay, from the lowest: compound 4; then compounds 2, 1 and 3 (each within the scatter of the next).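

In this assay, going by these compounds alone, the bare phenyl on the carbonyl carbon is the first change at this position to go beyond the scatter: a 3.6-fold lower number from compound 3 to compound 4 (0.56 log units; beyond the scatter), a 2.6-fold lower number from compound 2 to compound 4 (0.41 log units; beyond the scatter) and a 3.3-fold lower number from compound 1 to compound 4 (0.52 log units; beyond the scatter). The last step keeps the amide and removes only the trifluoromethyl, so among these compounds the lower number does not depend on the urea link. Nothing available accounts for this drop.

On these data alone, whether a single chloro on that phenyl would restore the higher number remains open. So does the reading with a methoxy, an amine or a carboxylic acid on the phenyl, or with cyclohexyl in its place.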